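A Larger Aryl Group Enters an Adenosine Receptor Ligand

The compounds below may be only part of what the source reports. "The series", "measured", "known", "first", "only" and "open" are said of these compounds alone.

Of the compounds shown here, two built on the same core have been measured in an assay on CHO-K1 cells for displacement of a labelled ligand from adenosine receptor A1 (Homo sapiens), read by scintillation counting, with a stated time of 60 min; a lower number here means a stronger inhibitor, a higher number a weaker inhibitor. Compound 2 `Nc1nc(N/N=C/c2cncs2)nc2c1ncn2[C@@H]1O[C@H](CO)[C@@H](O)[C@H]1O` gives 22 nM in this assay, the lowest of the two numbers. Compound 1 `COc1cc(/C=N/Nc2nc(N)c3ncn([C@@H]4O[C@H](CO)[C@@H](O)[C@H]4O)c3n2)ccc1OCc1ccccc1` carries a different group in the same place and gives 9140 nM in this assay, a far weaker result that lies well beyond the scatter. Compound 3 `CC(=O)Nc1ccc(/C=N/Nc2nc(N)c3ncn([C@@H]4O[C@H](CO)[C@@H](O)[C@H]4O)c3n2)cc1` has not yet been measured. It differs from compound 2 in one place: 4-acetamidophenyl in place of 1,3-thiazol-5-yl on a carbon with a double bond to nitrogen. Among the measured compounds shown here, a small five-membered aromatic ring thus gives way to a six-membered aromatic ring of carbon only that bears an acetamido group. Because compound 1, which also carries a six-membered aromatic ring of carbon only in that place, gives 9140 nM, a step toward weaker binding is expected, of the size an 18-fold higher number from compound 2 to compound 3 (1.26 log units; beyond the scatter). Compound 3 is therefore estimated at 400 nM, with a likely range from 80 nM to 2500 nM.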

Compound 3, inhibition constant: > 10000 nM
Compound 3: a limit, no number; the forecaster's own chance of this, stated with the estimate: 5%; at least 25-fold (1.39 log units) between middle value and limit.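

In this assay compound 3 gives > 10000 nM, which is a limit and not a number. Even so, 4-acetamidophenyl in place of 1,3-thiazol-5-yl produces an at least 450-fold higher number from compound 2 to compound 3 (2.65 log units; beyond the scatter), so weak binding at this position now appears with a second six-membered aromatic ring of carbon only, one that bears a different substituent from the ring in compound 1. The full size of this step cannot be read, because the value for compound 3 stands at a limit: the limit of > 10000 nM in this assay, at which 1 of the 3 values shown sits.

The compounds shown leave open whether the loss follows from the six-membered ring itself or from the acetamido group on it, a question that an unsubstituted phenyl group in the same place would address. Also open, from the compounds shown here alone, is how that ring would behave with a smaller group, such as an amine, in place of the acetamido group.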